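Removing a Methoxy Group from Compound 3

A few compounds are considered here, and "the series" means these few. Any claim that something is new, unique, unknown or untested is made for them only; others in the source may bear on it.

Compound 1 `O=C(/C=C\Nc1cnc2ccccc2c1)c1nc(-c2ccccc2)n2ccccc12`, compound 2 `COc1ccc(N/C=C\C(=O)c2nc(-c3ccc(F)cc3)n3ccccc23)cc1` and compound 3 `COc1ccc(N/C=C\C(=O)c2nc(-c3ccc(OC)cc3)n3ccccc23)cc1` share one core and were tested in a functional assay on BT-474 cells (Homo sapiens) for cytotoxicity, read by MTT assay, with a stated time of 48 h; on this read-out higher numbers stand for weaker inhibition and lower numbers for stronger inhibition. In this assay compound 1 gives 19700 nM, compound 2 gives 15700 nM and compound 3 gives 15400 nM. Compound 3 thus shows the lowest of the three numbers, yet its gaps to compound 2 and compound 1 lie within the scatter. Among the compounds with values here, the only single-site step, a 1.0-fold lower number from compound 2 to compound 3 (0.01 log units; within the scatter), changes nothing beyond the scatter. Compound 4 `COc1ccc(N/C=C\C(=O)c2nc(-c3ccccc3)n3ccccc23)cc1` differs from compound 3 by hydrogen in place of methoxy on an aromatic carbon. Within the data shown here, no measured step removes a methoxy group, and the one swap of groups at that place was flat, so no step beyond the scatter is expected. Compound 4 is therefore expected to give 16000 nM, between 8000 nM and 32000 nM, an expected 1.0-fold higher number from compound 3 to compound 4 (0.02 log units; within the scatter).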

Compound 4, half-maximal inhibitory concentration: 12800 nM
Estimate against measurement, compound 4: 1.3-fold (0.10 log units) above, and the stated range covers the measured number.
By their numbers in this assay, from the lowest: compounds 4, 3, 2 and 1 (each within the scatter of the next).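

In this assay, removing the methoxy from this carbon, para to a large group, gives a 1.2-fold lower number from compound 3 to compound 4 (0.08 log units; within the scatter), and hydrogen in place of fluoro gives a 1.2-fold lower number from compound 2 to compound 4 (0.09 log units; within the scatter), so the bare phenyl ring shifts the number no more than the substituted rings do. With this phenyl ring in place, 4-methoxyphenyl in place of quinolin-3-yl on the amine nitrogen gives a 1.5-fold lower number from compound 1 to compound 4 (0.19 log units; within the scatter), which is again no real change. Nothing measured here offers a reason for this flatness. Going by these compounds, whether an amine, a carboxylic acid or a longer chain on this ring carbon would move the number beyond the scatter remains open.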